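A few compounds are considered here, and "the series" means these few. Any claim that something is new, unique, unknown or untested is made for them only; others in the source may bear on it.

Three compounds share one core and were compared in a functional assay on HPAC cells (Homo sapiens) for inhibition, read by MTT assay, with a stated time of 72 h; on this read-out higher numbers stand for weaker inhibition of growth and lower numbers for stronger inhibition of growth. Compound 3 `O=S(=O)(NCCCNCc1ccccc1)c1cc(C(F)(F)F)cc(C(F)(F)F)c1` gives 3200 nM and stands second highest of the three numbers. Compound 1 `COc1ccc(CNCCCNS(=O)(=O)c2cc(C(F)(F)F)cc(C(F)(F)F)c2)cc1OC` gives 3500 nM in this assay, and compound 2 `O=S(=O)(NCCCNCC1COc2ccccc2O1)c1cc(C(F)(F)F)cc(C(F)(F)F)c1` gives 2700 nM. The steps of a 1.1-fold lower number from compound 1 to compound 3 (0.04 log units; within the scatter) and a 1.2-fold higher number from compound 2 to compound 3 (0.07 log units; within the scatter) both lie within the scatter, so swapping the ring on the saturated chain carbon bound to an amine nitrogen has left the read-out essentially unchanged. Compound 4 `O=S(=O)(NCCCNCc1cccc(Cl)c1)c1cc(C(F)(F)F)cc(C(F)(F)F)c1` carries chloro in place of hydrogen on an aromatic carbon and is not yet measured. Since every measured change at this ring produced no step beyond the scatter, the expected step of a 1.1-fold lower number from compound 3 to compound 4 (0.03 log units; within the scatter) is also small, in no particular direction. Compound 4 is therefore estimated at 3000 nM, within a range from 1500 nM to 6000 nM.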

Compound 4, concentration for 50% growth inhibition: 2700 nM
Compound 4: the middle estimate sits 1.1-fold (0.05 log units) above what was measured, and the stated range covers the measured number.
By their numbers in this assay, from the lowest: compounds 2, 4, 3 and 1 (each within the scatter of the next).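

With a 1.2-fold lower number from compound 3 to compound 4 (0.07 log units; within the scatter) in this assay, chloro placed on the phenyl ring itself, and not only a swap of the whole ring, leaves the read-out essentially unchanged. The 3-chlorophenyl group also matches the other two rings, with no change at the digits printed from compound 2 to compound 4 (within the scatter) and a 1.3-fold lower number from compound 1 to compound 4 (0.11 log units; within the scatter) as the remaining steps. No supporting data are available to explain this flat picture. Still open, as far as these compounds go, is whether a carboxylic acid or an amine on the phenyl ring, or a plain alkyl chain in place of that ring, would give a step beyond the scatter.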